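Chloro for Fluoro on the Shared Core

This account rests on a few compounds, and the source may have more. Where it says the series, first, only, none or still open, it means among the compounds named here.

Compound 1 `c1ccc(-c2nc3cccnc3o2)cc1` and compound 2 `Fc1cccc(-c2nc3cccnc3o2)c1` share one core and differ only at one aromatic carbon. In a functional assay on the whole organism for inhibition, with Rattus norvegicus as the target, at a dose of 30 mg/kg (on this read-out higher numbers stand for more inhibition at the one dose given (going by the name of the read-out) and lower numbers for less inhibition), compound 1 gives 55%, and compound 2 gives 35%. For the measured compounds named here, compound 2 therefore holds the lowest of the two numbers, and the one measured step, a number 20 percentage points lower from compound 1 to compound 2 (beyond the scatter), is the change of fluoro in place of hydrogen on an aromatic carbon. Compound 3 `Clc1cccc(-c2nc3cccnc3o2)c1` carries the change (chloro in place of fluoro on an aromatic carbon), chloro in place of fluoro on an aromatic carbon. Going by the values given here, no measured step shows a chloro, so the only guide is that a halogen at this carbon, in compound 2, sat at 35%. The step is expected to be a number 3 percentage points higher from compound 2 to compound 3 (within the scatter), in no clear direction beyond the scatter. Compound 3 is therefore estimated at 38%, within 15% to 60%.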

Compound 3, a percentage reported as inhibition, in the whole organism at one dose (the size of the read-out at that dose, not a potency): 8%
The estimate for compound 3 lay 30 percentage points above the measured number, and the stated range ends above it.
By their numbers in this assay, from the lowest: compound 3; then compound 2; then compound 1.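

The halogen at this carbon is not interchangeable: in this assay, chloro in place of fluoro gives a number 27 percentage points lower from compound 2 to compound 3 (beyond the scatter), so the two halogens are clearly separated at this position. Set against the hydrogen of compound 1, the chloro change gives a number 47 percentage points lower from compound 1 to compound 3 (beyond the scatter), which shows that both halogens on the listed compounds lower the read-out and that chloro, in compound 3, does so to the greater extent. Nothing available here accounts for the difference between fluoro and chloro at this carbon.

As far as these compounds go, whether a methoxy group or an amine on this same aromatic carbon would fall as the halogens do or stay near compound 1 remains open. Also open, from the compounds shown here alone, is whether chloro on another carbon of this ring would lower the read-out in the same way.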